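Swapping the amine side chain of compound 1

A few compounds are considered here, and "the series" means these few. Any claim that something is new, unique, unknown or untested is made for them only; others in the source may bear on it.

Measured compounds:
compound 1, `CCc1nc(-c2ccc(Cl)cc2Cl)c(CC)nc1NC(CC)CC`, 0.07 h
compound 2, `CCOc1nc(-c2ccc(Cl)cc2Cl)c(CC)nc1NC(CC)CC`, 1.23 h
compound 3, `CCc1nc(NC(CC)CC)c(Cl)nc1-c1ccc(Cl)cc1Cl`, < 0.0167 h

In an in vitro ADME assay on microsomes (Rattus norvegicus) for metabolic stability (a lower number here means that the compound disappears faster, a higher number that the compound lasts longer), compound 1 gives 0.07 h, the lower of the two numbers recorded; compound 2 lies an 18-fold higher number from compound 1 to compound 2 (1.24 log units; beyond the scatter) away. For compound 3 the read-out is a limit, < 0.0167 h, and it sits at the limit of < 0.0167 h in this assay, at which 1 of the 3 values shown sits. Compound 4, `CCc1nc(-c2ccc(Cl)cc2Cl)c(CC)nc1NC(COC)COC`, differs from compound 1 by 2-methoxy-1-(methoxymethyl)ethyl in place of pentan-3-yl on a nitrogen on an aromatic ring. Among the measured compounds shown here, none of the measured steps touches this nitrogen: an at least 4.1-fold lower number from compound 1 to compound 3 (0.62 log units; beyond the scatter) and an at least 73-fold lower number from compound 2 to compound 3 (1.86 log units; beyond the scatter) both concern an aromatic carbon, so they do not bear on the change. The expectation therefore rests on compound 1 alone, with no step beyond the scatter foreseen. Compound 4 is estimated at 0.1 h, between 0.04 h and 0.35 h, which means a step of a 1.4-fold higher number from compound 1 to compound 4 (0.15 log units; within the scatter) expected to remain within the scatter.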

Compound 4, half-life: 0.0417 h
Compound 4: middle estimate off by 2.4-fold (0.38 log units), on the high side; measured number inside the range.
By their numbers in this assay, from the lowest: compounds 4 and 1 (each within the scatter of the next); then compound 2. At a limit, below all of these: compound 3.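

In this assay, exchanging pentan-3-yl for 2-methoxy-1-(methoxymethyl)ethyl on this nitrogen gives a 1.7-fold lower number from compound 1 to compound 4 (0.22 log units; within the scatter), so this change stays within the scatter, whereas the steps on the aromatic carbon among compounds 1, 2 and 3 all went beyond it. Among the compounds shown here, compound 4 thus gives the first reading at this nitrogen, and it leaves the number where compound 1 had it. Nothing measured here accounts for this result. From the compounds shown here alone, whether an amine, a carboxylic acid or a cyclopentyl ring on this nitrogen would behave alike remains open. So does whether ethoxy on the aromatic carbon would raise the number with 2-methoxy-1-(methoxymethyl)ethyl in place.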